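Swapping the amine substituent on a shared core

The source may report more compounds than this note shows. Statements on the series, on what has been measured and on what is new or still open speak of the compounds shown alone.

Compound 1: `C[C@@H](Cn1ccc(-c2ccc(C#N)c(Cl)c2)n1)NC(=O)c1ccccc1F`, 1810 nM
Compound 2: `C[C@@H](Cn1ccc(-c2ccc(C#N)c(Cl)c2)n1)NS(=O)(=O)c1cccnc1`, 6140 nM
Compound 3: `C[C@@H](Cn1ccc(-c2ccc(C#N)c(Cl)c2)n1)Nc1ccncc1`, 2560 nM

Three compounds sharing one core were tested in a functional assay on LNCaP cells (Homo sapiens) for antiproliferative activity, read by CCK-8 assay, with a stated time of 6 days; a higher number here means a weaker inhibitor, a lower number a stronger inhibitor. Compound 1 gives 1810 nM, compound 2 gives 6140 nM, and compound 3 gives 2560 nM, which places compound 3 second highest of the three numbers: one of its gaps is a 1.4-fold higher number from compound 1 to compound 3 (0.15 log units; within the scatter), within the scatter, while the other is a 2.4-fold lower number from compound 2 to compound 3 (0.38 log units; beyond the scatter), beyond it. The step in question leads to compound 4, `Cc1ccnc(N[C@@H](C)Cn2ccc(-c3ccc(C#N)c(Cl)c3)n2)n1`, which differs from compound 3 by 4-methylpyrimidin-2-yl in place of pyridin-4-yl on an amine nitrogen. For the measured compounds named here, no measured step covers an exchange between two aromatic rings on this nitrogen; the measured steps of a 3.4-fold higher number from compound 1 to compound 2 (0.53 log units; beyond the scatter) and a 1.4-fold higher number from compound 1 to compound 3 (0.15 log units; within the scatter) only show that changes at this position move this assay modestly at most. The step of a 1.2-fold lower number from compound 3 to compound 4 (0.07 log units; within the scatter) is therefore expected to stay near or within the scatter. Compound 4 is estimated at 2200 nM, with a range from 800 nM to 6500 nM.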

Compound 4, half-maximal inhibitory concentration: 1330 nM
Compound 4: the middle estimate sits 1.7-fold (0.22 log units) above what was measured; the range from low to high includes it.
By their numbers in this assay, from the lowest: compounds 4, 1 and 3 (each within the scatter of the next); then compound 2.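

For the compounds shown here, this is the first exchange of one aromatic ring for another directly on the amine nitrogen, and in this assay 4-methylpyrimidin-2-yl and pyridin-4-yl cannot be told apart (a 1.9-fold lower number from compound 3 to compound 4 (0.28 log units; within the scatter)). With compound 4, the amide of compound 1 also stays within the scatter of a ring-bearing amine (a 1.4-fold lower number from compound 1 to compound 4 (0.13 log units; within the scatter)), while the sulfonamide compound 2 stands apart as the weakest of the four (a 4.6-fold lower number from compound 2 to compound 4 (0.66 log units; beyond the scatter)). No evidence at hand accounts for these differences.

The entering group adds both a methyl and a second ring nitrogen, and the compounds shown do not separate the two, since they include neither unsubstituted pyrimidin-2-yl nor 4-methylpyridin-2-yl. They also leave open how a saturated ring such as piperidin-4-yl or a plain acetyl on this nitrogen would read.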